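This account rests on a few compounds, and the source may have more. Where it says the series, first, only, none or still open, it means among the compounds named here.

Compound 1 `Cc1ccc(OCC(=O)N(Cc2cccs2)C2COC2)cc1` stands at the weak end of the three compounds measured in an assay on HEK293 cells for agonist activity at transient receptor potential cation channel subfamily M member 8 (Homo sapiens), read by fluorescence and calcium flux, with a stated time of 15 min; on this read-out higher numbers stand for an effect only at larger amounts of compound and lower numbers for an effect already at smaller amounts: compound 1 gives 23000 nM, whereas compound 3 `CCc1ccc(OCC(=O)N(CC)Cc2cccs2)cc1` gives 67 nM and compound 2 `O=C(COc1ccc2c(c1)CCC2)N(Cc1cccs1)c1ccn[nH]1` gives 0.001 nM, both of them far beyond the scatter from compound 1. The new compound 4 `Cc1ccc(OCC(=O)N(Cc2cccs2)c2c(C)n[nH]c2C)cc1` keeps the shared core of compound 1 and alters only the substituent on the amide-type nitrogen: 3,5-dimethyl-1H-pyrazol-4-yl in place of oxetan-3-yl on an amide-type nitrogen. Going by the values given here, no measured pair isolates this exact change, yet the three values together suggest that what sits on this nitrogen matters greatly, because compound 2 gives 0.001 nM. He therefore expects a large step downward in this assay from compound 1 to compound 4, a 77-fold lower number from compound 1 to compound 4 (1.88 log units; beyond the scatter), and estimates for compound 4 a value of 300 nM, within a range from 10 nM to 6000 nM.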

Compound 4, half-maximal effective concentration: 0.3 nM
Compound 4: middle estimate off by 1000-fold (3.00 log units), on the high side; the whole stated range lies above it.
By their numbers in this assay, from the lowest: compound 2; then compound 4; then compound 3; then compound 1.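

In this assay, 3,5-dimethyl-1H-pyrazol-4-yl in place of oxetan-3-yl on the amide-type nitrogen gives a large step (a 77000-fold lower number from compound 1 to compound 4 (4.88 log units; beyond the scatter)). Going by these compounds alone, this is the first pair to differ in this one place, and it shows that this substituent alone, with the rest of compound 1 unchanged, can move the number this far. Nothing measured here explains the step. The compounds shown leave open whether the two methyl groups or the ring's nitrogen-bound hydrogen matter to it. They also leave open how a phenyl ring on this nitrogen would compare.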